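Bromo in Place of Fluoro: What to Expect for Compound 4

The compounds below may be only part of what the source reports. "The series", "measured", "known", "first", "only" and "open" are said of these compounds alone.

In an ADME assay on HEK-293T cells (Homo sapiens) for cytotoxicity, read by MTT assay, with a stated time of 24 h (a higher number here means that more compound is tolerated, a lower number that less compound is tolerated), compound 1 `O=S(=O)(c1ccccc1)n1c(-c2cn(-c3ccccc3)nc2-c2ccc(F)cc2)nc2ccccc21` gives 96300 nM, compound 2 `O=[N+]([O-])c1ccc(S(=O)(=O)n2c(-c3cn(-c4ccccc4)nc3-c3ccc(F)cc3)nc3ccccc32)cc1` gives 189000 nM and compound 3 `O=S(=O)(c1ccc(F)cc1)n1c(-c2cn(-c3ccccc3)nc2-c2ccc(F)cc2)nc2ccccc21` gives 218000 nM. Compound 3 thus sits level with compound 2 and higher than compound 1. Compound 4 `O=S(=O)(c1ccc(Br)cc1)n1c(-c2cn(-c3ccccc3)nc2-c2ccc(F)cc2)nc2ccccc21` changes 4-fluorophenyl to 4-bromophenyl: bromo in place of fluoro on an aromatic carbon. Among the compounds with values here, no measured compound carries bromo. The closest parallel is a 1.2-fold higher number from compound 2 to compound 3 (0.06 log units; within the scatter), where one group replaces another at this spot. Adding a group in place of hydrogen gave a 2.0-fold higher number from compound 1 to compound 2 (0.29 log units; within the scatter) and a 2.3-fold higher number from compound 1 to compound 3 (0.35 log units; beyond the scatter), the latter only a modest step. No change beyond the scatter is therefore expected in this assay. The expected step is a 1.1-fold lower number from compound 3 to compound 4 (0.06 log units; within the scatter). Compound 4 is estimated at 190000 nM, with an expected range from 95000 nM to 380000 nM.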

Compound 4, half-maximal cytotoxic concentration: 239000 nM
Compound 4: middle estimate off by 1.3-fold (0.10 log units), on the low side, within the range that was stated.
By their numbers in this assay, from the lowest: compounds 1, 2, 3 and 4 (each within the scatter of the next, the first and the last beyond it).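

In this assay, bromo in place of fluoro leaves the number level, with a 1.1-fold higher number from compound 3 to compound 4 (0.04 log units; within the scatter), and compound 4 is also level with the nitro-bearing compound, with a 1.3-fold higher number from compound 2 to compound 4 (0.10 log units; within the scatter). Against the compound with hydrogen at this spot, bromo gives a modest step beyond the scatter, with a 2.5-fold higher number from compound 1 to compound 4 (0.39 log units; beyond the scatter), as fluoro did, whereas nitro in compound 2 stays within it. No supporting data bear on these readings.

Still open, on these data alone, is whether an amine or a carboxylic acid on this aromatic carbon would stay level with compound 3 and compound 4.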